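Notes on a methoxy substitution within the amide series

The compounds below may be only part of what the source reports. "The series", "measured", "known", "first", "only" and "open" are said of these compounds alone.

Compound 1 `O=C(C/C=C/c1ccccc1)Nc1nc2ccccc2c(=O)s1` is the reference point of this set. In an assay on membranes from brain for displacement of a labelled ligand from adenosine receptor A1 (Rattus norvegicus), read by scintillation counting, with a stated time of 90 min (a lower number here means a stronger inhibitor, a higher number a weaker inhibitor), compound 1 gives 53 nM, the lowest of the two numbers measured. Compound 3 `O=C(CCCc1cccc(Cl)c1)Nc1nc2ccccc2c(=O)s1`, the nearest neighbour in value, gives 898 nM in this assay, a higher number than compound 1 by a gap that lies beyond the usual scatter of repeat measurements. Compound 2 `O=C(COc1cccc(Cl)c1)Nc1nc2ccccc2c(=O)s1` reaches only a limit of the assay in this assay, namely > 10000 nM, so no number is known for it. Compound 2 sits at the limit of > 10000 nM in this assay, at which 1 of the 3 values shown sits.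

Among the measured compounds shown here, no pair of measured compounds differs in a single place, so the data give no direct calibration for what one substitution does in this assay. For a small change of one group on the aromatic ring the expectation is a step in this assay that stays within the scatter, with no firm direction.

Compound 4 `COc1cccc(/C=C/CC(=O)Nc2nc3ccccc3c(=O)s2)c1` differs from compound 1 by methoxy in place of hydrogen on an aromatic carbon. Compound 4 is expected to give about 60 nM in this assay, with a likely range from 20 nM to 200 nM. The expected step of a 1.1-fold higher number from compound 1 to compound 4 (0.05 log units; within the scatter) is estimated to fall within the usual scatter.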

Compound 4, inhibition constant: 11.2 nM
Beside the measured number, compound 4's estimate is 5.4-fold (0.73 log units) above it; measured number outside the range, below it.
By their numbers in this assay, from the lowest: compound 4; then compound 1; then compound 3. At a limit, above all of these: compound 2.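

Among the compounds shown here, this is the first step in the set that can be read for a single change, and it replaces the open expectation with a measured direction and size. In this assay, phenyl to 3-methoxyphenyl gives a 4.7-fold lower number from compound 1 to compound 4 (0.68 log units; beyond the scatter), so this aromatic carbon, meta to a large group, is not a silent place in the series: it accepts methoxy, and the number falls by a step that lies beyond the usual scatter of repeat measurements. No measured property among the data at hand bears on this step, so the result stands as an observation without an explanation.

From the compounds shown here alone, it remains open whether the step belongs to methoxy itself or would appear with other groups at the same place; a methyl group, a hydroxyl group or an ethoxy group on that aromatic carbon would help separate these readings. It also remains open whether methoxy on the other carbons of the aromatic ring would give a step of like direction and size, since the compounds shown sample this one place only.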